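Thioether substituent exchange on the shared core

The source may report more compounds than this note shows. Statements on the series, on what has been measured and on what is new or still open speak of the compounds shown alone.

Measured so far:
compound 1, `N#Cc1c(N)nc(SCc2nnn[nH]2)c(C#N)c1-c1ccc(OCC2CC2)cc1`, gives 1% in an assay on CHO cells for displacement of a labelled ligand from adenosine receptor A3 (Homo sapiens), read by scintillation counting, with a stated time of 120 min, tested at 1 uM; a higher number here means more inhibition at the concentration tested (going by the name of the read-out), a lower number less inhibition
compound 2, `N#Cc1c(N)nc(SCc2csc(N)n2)c(C#N)c1-c1ccc(OCC2CC2)cc1`, gives 1% in this assay

Compound 2 stands level with compound 1 at the digits shown: no change at the digits printed from compound 1 to compound 2 (within the scatter). Compound 3, `CNC(=O)CSc1nc(N)c(C#N)c(-c2ccc(OCC3CC3)cc2)c1C#N`, differs from compound 2 by methylcarbamoyl in place of 2-amino-1,3-thiazol-4-yl on a saturated chain carbon bound to a sulfur. Among the compounds with values here, the only measured step, no change at the digits printed from compound 1 to compound 2 (within the scatter), exchanged one ring group for another on that carbon and left the read-out unchanged; no measured step replaces the ring with a chain group, so its bearing on compound 3 is loose. With both measured compounds at the bottom of the scale, the expected step in this assay is none beyond the scatter, a number 2 percentage points higher from compound 2 to compound 3 (within the scatter). Compound 3 is estimated at 3%, in the range -8% to 20%.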

Compound 3, a percentage reported as inhibition, at one concentration (the size of the read-out at that concentration, not a potency): 3%
Compound 3: the middle estimate sits on the measured number at the digits printed; measured number inside the range.
By their numbers in this assay, from the lowest: compounds 1, 2 and 3 (each within the scatter of the next).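

The exchange of a ring for a chain group on a saturated chain carbon bound to a sulfur now has a measured result in this assay: methylcarbamoyl in place of 2-amino-1,3-thiazol-4-yl (a number 2 percentage points higher from compound 2 to compound 3 (within the scatter)) and in place of 1H-tetrazol-5-yl (a number 2 percentage points higher from compound 1 to compound 3 (within the scatter)). Neither ring separates from the chain group at this position, so all three substituents read alike. No measured evidence accounts for this. On these data alone, whether a carboxylic acid, an amine or a longer chain on that carbon would move the read-out beyond the scatter stays open.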